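The source may report more compounds than this note shows. Statements on the series, on what has been measured and on what is new or still open speak of the compounds shown alone.

Compound 1 `CCN(CC)CCCOc1cc2ncnc(Nc3ccc(C#N)cc3)c2cc1OC` gives 59400 nM in a functional assay on HepG2 cells (Homo sapiens) for antiproliferative activity, read by MTT assay, with a stated time of 72 h; a higher number here means a weaker inhibitor, a lower number a stronger inhibitor. Compound 2 `COc1cc2c(Nc3ccc(C#N)cc3)ncnc2cc1OCCCN1CCC(C)CC1` gives 32100 nM in this assay. Compound 3 `COc1cc2c(Nc3ccc(C#N)cc3)ncnc2cc1OCCCN1CCCCC1CCO` gives only a limit of the assay, > 100000 nM, in this assay.

Among these, compound 1 and compound 2 sit within the scatter of each other, as a 1.9-fold lower number from compound 1 to compound 2 (0.27 log units; within the scatter) shows, so no order between them can be claimed, while compound 3 contributes a limit rather than a number (the limit of > 100000 nM in this assay, at which 1 of the 3 values shown sits).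

The unmeasured compound 4 `COc1cc2c(Nc3ccc(C#N)cc3)ncnc2cc1OCCCN1CCN(C)CC1` differs from compound 1 in one place: 4-methylpiperazin-1-yl in place of diethylamino on a saturated chain carbon, three bonds along the chain from an oxygen on an aromatic ring. For the measured compounds named here, three measured steps bear on this. Replacing diethylamino with a ring amine, 4-methylpiperidin-1-yl, gave a 1.9-fold lower number from compound 1 to compound 2 (0.27 log units; within the scatter). Replacing it with 2-(2-hydroxyethyl)piperidin-1-yl gave an at least 1.6-fold higher number from compound 1 to compound 3 (0.22 log units; that floor lies within the scatter). Between the two ring amines the step was an at least 3.1-fold higher number from compound 2 to compound 3 (0.49 log units; beyond the scatter), but that step ends at a limit.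

For the change from diethylamino to 4-methylpiperazin-1-yl, another six-membered ring amine, the nearest comparison is compound 2, whose step a 1.9-fold lower number from compound 1 to compound 2 (0.27 log units; within the scatter) stayed within the scatter. Compound 4 is therefore expected to show a 1.3-fold lower number from compound 1 to compound 4 (0.12 log units; within the scatter), no movement beyond the scatter in this assay. The estimated value for compound 4 is 45000 nM, within a range of 15000 nM to 100000 nM.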

Compound 4, half-maximal inhibitory concentration: 13800 nM
The estimate for compound 4 lay 3.3-fold (0.51 log units) above the measured number; the whole stated range lies above it.
By their numbers in this assay, from the lowest: compound 4; then compounds 2 and 1 (each within the scatter of the next). At a limit, above all of these: compound 3.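

In this assay, for the compounds shown here, no earlier step away from diethylamino at this position, on a saturated chain carbon three bonds along the chain from an oxygen on an aromatic ring, had moved the number beyond the scatter, but a 4.3-fold lower number from compound 1 to compound 4 (0.63 log units; beyond the scatter) does. The ring alone does not account for this, since compound 2 stayed within the scatter of compound 1, whereas the two six-membered rings now separate, with a 2.3-fold lower number from compound 2 to compound 4 (0.37 log units; beyond the scatter), so that the choice of ring amine matters at this position. The third new step, an at least 7.2-fold lower number from compound 3 to compound 4 (0.86 log units; beyond the scatter), is only a floor, as it starts from a limit and not a number: the limit of > 100000 nM in this assay, at which 1 of the 4 values shown sits.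

The compounds shown leave open whether the lower number in this series follows the second ring nitrogen of 4-methylpiperazin-1-yl or the methyl group on that nitrogen, a question that piperazin-1-yl and morpholin-4-yl on the same chain could help to settle. Also open, going by these compounds, is how much the chain length contributes, which 2-(4-methylpiperazin-1-yl)ethyl in place of 3-(4-methylpiperazin-1-yl)propyl would test.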